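This account rests on a few compounds, and the source may have more. Where it says the series, first, only, none or still open, it means among the compounds named here.

Working notes on the series in a functional assay on P388 cells (Mus musculus) for inhibition; on this read-out higher numbers stand for weaker inhibition and lower numbers for stronger inhibition.

Compound 1 `O=C1/C(=C/c2ccc(F)cc2)CCCc2ccccc21` gives 11100 nM, and compound 2 `O=C1/C(=C/c2ccc(Cl)cc2)CCCc2ccccc21` gives 9500 nM. The change between them is chloro in place of fluoro on an aromatic carbon, and it produced a 1.2-fold lower number from compound 1 to compound 2 (0.07 log units; within the scatter), so nothing in this pair separates chloro from fluoro at that place.

Compound 3 `O=C1CCCCC/C1=C\c1cccc(F)c1` is built on a different core; how its core differs from that of compound 1 is not broken down here. For compound 3 only a limit is known, > 50000 nM, not a number. This is the limit of > 50000 nM in this assay, at which 1 of the 3 values shown sits.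

Compound 4 `O=C1CCCCC/C1=C\c1cccc(Cl)c1` is the one not yet measured. It differs from compound 3 by chloro in place of fluoro on an aromatic carbon. Among the measured compounds shown here, this is the same kind of change as the one from compound 1 to compound 2, though the surroundings are not identical: in the earlier pair the substituent sits para to a large group, here it sits meta to a group of 9 heavy atoms.

The expectation for compound 4 is a step that the limit leaves unreadable from compound 3 to compound 4, essentially no movement, because the earlier instance of the same kind of change gave a 1.2-fold lower number from compound 1 to compound 2 (0.07 log units; within the scatter) and because the parent here, compound 3, reached only a limit at > 50000 nM. Compound 4 is therefore estimated at 55000 nM, with an expected range from 20000 nM to 150000 nM, and a fair chance that only a limit is again reported.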

Compound 4, half-maximal inhibitory concentration: 25700 nM
Beside the measured number, compound 4's estimate is 2.1-fold (0.33 log units) above it; the range from low to high includes it.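

In this assay, chloro in place of fluoro on an aromatic carbon gives an at least 1.9-fold lower number from compound 3 to compound 4 (0.28 log units; that floor lies within the scatter), so the change on this second core moves the read-out from a limit to a measured number, but the floor of that step does not establish a real difference between chloro and fluoro. Compound 3 reads > 50000 nM, which is a limit and not a number, so the step has a floor and no measured size, and its true size could be either small or large. The two instances therefore show that the change can be placed on both cores without a higher number appearing in either pair, but they do not show that its size carries over from one core to the other: the same change on two cores in this assay, a 1.2-fold lower number (0.07 log units; within the scatter) from compound 1 to compound 2 and an at least 1.9-fold lower number (0.28 log units; that floor lies within the scatter) from compound 3 to compound 4; the limit leaves it open whether they differ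

The compounds shown carry only fluoro or chloro on the aromatic ring, so it remains open whether a methoxy group, an amine or a carboxylic acid at the same place would shift the number on either core. On these data alone, it also remains open how large the step from compound 3 to compound 4 really is, since a measured number for a fluoro compound on this core would be needed to settle it.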